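Lipophilicity notes on a triazolyl-indole series

This account rests on a few compounds, and the source may have more. Where it says the series, first, only, none or still open, it means among the compounds named here.

Measured so far:
compound 1 `CC(C)Sc1nnc(-c2c(CNc3cnccn3)c3ccccc3n2C)n1-c1ccccc1` — 4.22
compound 2 `COc1ccc(CNCc2c(-c3nnc(SC(C)C)n3-c3ccccc3)n(C)c3ccc(F)cc23)cc1` — 6.42

In a physicochemical assay for lipophilicity (a higher number here means a more lipophilic compound, a lower number a more polar compound), compound 1 gives 4.22, the lower of the two numbers available. Compound 2 gives 6.42 in this assay, a gap that lies beyond the scatter; the two compounds differ in several places at once, so no single step can be read from them.

Compound 3 `CC(C)Sc1nnc(-c2c(CNc3nc4ccccc4[nH]3)c3ccccc3n2C)n1-c1ccccc1` has not yet been measured. Relative to compound 1 the change is 1H-benzimidazol-2-yl in place of pyrazin-2-yl on an amine nitrogen. Within the data shown here, no step between measured compounds covers this exchange, so the expectation rests on the change itself: a larger group with more carbon entering on the amine nitrogen, which is expected to push this assay upward by a moderate amount rather than by a shift as large as the gap between compound 1 and compound 2.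

Compound 3 is therefore expected to come out at 5.2, with a likely range of 4.6 to 5.8. The expected step of a number 0.98 log units higher from compound 1 to compound 3 (beyond the scatter) is taken as a rise beyond the scatter. The measurement will decide.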

Compound 3, partition coefficient: 5.94
Beside the measured number, compound 3's estimate is 0.74 log units below it; the measured number lies above the stated range.
By their numbers in this assay, from the lowest: compound 1; then compound 3; then compound 2.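

In this assay, among these compounds, the exchange on the amine nitrogen gives the first step that can be read at a single place: the step is a number 1.72 log units higher from compound 1 to compound 3 (beyond the scatter) with 1H-benzimidazol-2-yl in place of pyrazin-2-yl and the rest of the structure unchanged. The number at this position therefore depends strongly on the group carried there, at least for this pair, and the exchange adds carbon atoms, replaces the six-membered aromatic ring with 2 hetero atoms by a five-membered aromatic ring with 2 hetero atoms plus a six-membered aromatic ring of carbon only, and brings a hydrogen-bond donor that the leaving group lacks. No independent measurement ties the step to any one of these differences, so it describes the exchange as a whole.

A phenyl group or a 1-methyl-1H-benzimidazol-2-yl group on the same amine nitrogen would help separate the added carbon atoms from the added hydrogen-bond donor. Going by these compounds, how far a single change elsewhere on the shared core, such as a carboxylic acid in place of the propan-2-ylthio chain, would move the number remains open.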